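Methoxy in Place of Hydrogen in a Small Series

This account rests on a few compounds, and the source may have more. Where it says the series, first, only, none or still open, it means among the compounds named here.

The measured compounds:
compound 1, `CCCc1nc(-c2ccccc2)c(CNCCCN2CCN(c3cccc(C)c3)CC2)o1`, which in an assay on HEK293 cells for inhibition of Voltage-dependent T-type calcium channel subunit alpha-1G (Homo sapiens), read by fluorescence, tested at 10 uM (a lower number here means less inhibition, a higher number more inhibition at the concentration tested (going by the name of the read-out)), gives 47.8%
compound 2, `CCCc1nc(-c2ccccc2)c(CNCCN2CCN(c3ccccc3)CC2)o1`, which gives 54.3%
compound 3, `CCCc1nc(-c2ccccc2)c(CNCCCN2CCN(c3ccccc3C)CC2)o1`, which gives 54.5%

Compound 2 sits in the middle of these three numbers: compound 3 is nearest, higher by a margin within the scatter, and compound 1 is furthest, lower but also within the scatter. The three values therefore sit together as one group.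

Compound 4, `CCCc1nc(-c2ccccc2)c(CNCCN2CCN(c3ccccc3OC)CC2)o1`, arises from compound 2 by a single change: methoxy in place of hydrogen on an aromatic carbon. Among the measured compounds shown here, only one step between measured compounds alters a single feature, a number 6.7 percentage points higher from compound 1 to compound 3 (within the scatter), in which a methyl moves from one aromatic carbon to another. That step concerns a methyl rather than a methoxy and stays within the scatter, so it bears only loosely on the present change. Compounds 2 and 3 differ in more than one place, and their values are nearly the same.

Nothing here points to a shift beyond the scatter. Compound 4 is therefore expected to show a step of a number 0.3 percentage points lower from compound 2 to compound 4 (within the scatter). Compound 4 is estimated at 54%, within a range from 40% to 68%.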

Compound 4, a percentage reported as inhibition, at one concentration (the size of the read-out at that concentration, not a potency): 39.7%
For compound 4 the middle estimate is 14.3 percentage points above the measured one; the whole stated range lies above it.
By their numbers in this assay, from the lowest: compounds 4, 1, 2 and 3 (each within the scatter of the next, the first and the last beyond it).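

Going from phenyl to 2-methoxyphenyl gives a number 14.6 percentage points lower from compound 2 to compound 4 (beyond the scatter) in this assay and this is the first step between compounds that differ in one place to pass beyond the scatter. Among the compounds shown here, the only earlier step of that kind, the methyl shift that gives a number 6.7 percentage points higher from compound 1 to compound 3 (within the scatter) and stays within the scatter, could not show whether changes on this aromatic ring matter at all, whereas the new step shows that one added methoxy, ortho to a large group, can lower the inhibition seen at the single concentration tested, although the size of that drop remains modest. Nothing measured in this small series offers an explanation for the drop, so the result stands as an observation and not as a mechanism.

From the compounds shown here alone, whether the drop belongs to methoxy in particular or would also come with another group at the same place stays open, as a hydroxy, a fluorine, a chlorine or an ethoxy there would be needed to tell these apart. Also open, going by these compounds, is whether the same methoxy would give a step of similar size as 3-methoxyphenyl or 4-methoxyphenyl, which would show how much the place on the ring counts.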